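The source may hold more compounds than are shown below. What is called first, only, known or untested is meant among the compounds shown, and "the series" means these compounds.

Compound 1 `COc1ccc2[nH]c(-c3ccc[se]3)cc(=O)c2c1O` pairs a hydroxy group on its shared core with a five-membered selenium ring. In an ADME assay on Detroit 551 cells (Homo sapiens) for cytotoxicity, read by MTT assay, with a stated time of 48 h (on this read-out lower numbers stand for stronger inhibition and higher numbers for weaker inhibition), compound 1 gives 100000 nM. Compound 2 `COc1ccc2[nH]c(-c3ccc[se]3)cc(=O)c2c1` differs from compound 1 in a single place: hydrogen in place of hydroxy on an aromatic carbon. For compound 2 this assay reports only a limit, > 10000 nM. The step that the limit leaves unreadable from compound 1 to compound 2 cannot be sized because compound 2 sits at the limit of > 10000 nM in this assay, at which 1 of the 3 values shown sits.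

Compound 3 `COc1ccc2[nH]c(-c3cc[se]c3)cc(=O)c2c1O` keeps the hydroxy group of compound 1 but carries the selenium ring joined differently: a group of 5 heavy atoms (4 carbon, 1 selenium; one five-membered aromatic ring with 1 hetero atom) in place of a group of 5 heavy atoms (4 carbon, 1 selenium; one five-membered aromatic ring with 1 hetero atom), on an aromatic carbon. For compound 3 this assay again reports only a limit, > 100000 nM. Going by these compounds, the step of a number no lower from compound 1 to compound 3 (the limit leaves the size open) stays open because compound 3 sits at the limit of > 100000 nM in this assay, at which 1 of the 3 values shown sits.

Compound 4 `COc1ccc2[nH]c(-c3cc[se]c3)cc(=O)c2c1` is not yet measured in this assay. It stands to compound 3 exactly as compound 2 stands to compound 1: hydrogen in place of hydroxy on an aromatic carbon. The surroundings of the change read the same in both pairs, so this is the same change, not merely the same kind. Among the compounds with values here, its one measured instance, a step that the limit leaves unreadable from compound 1 to compound 2, gives no readable size, so the expectation for compound 4 rests on the values themselves rather than on a measured step. Compound 1 gives a number at the upper end of what this assay reports, and compound 2 and compound 3 each reach a limit. The step from compound 3 to compound 4 is therefore expected to be about a number no higher from compound 3 to compound 4 (the limit leaves the size open). Compound 4 is estimated at 100000 nM, likely between 30000 nM and 300000 nM, with the assay quite likely reporting only a limit.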

Compound 4, half-maximal inhibitory concentration: > 10000 nM
Compound 4 ended at the assay's limit (the forecaster's own chance of this, stated with the estimate: 80%); the middle value does not contradict the limit.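

Neither step to compound 4, from compound 2 or from compound 3, can be read, because compound 4, like compound 2, gives only a limit and compound 3 gives only a limit of its own: the limit of > 10000 nM in this assay, at which 2 of the 4 values shown sit.

The compounds shown leave open how much hydrogen in place of hydroxy, or the way the selenium ring is joined, shifts the number in this assay.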